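A few compounds are considered here, and "the series" means these few. Any claim that something is new, unique, unknown or untested is made for them only; others in the source may bear on it.

Measured compounds:
- compound 1, `O[C@H](c1ccccn1)[C@]1(c2cc(C(F)(F)F)ccn2)C[C@@H](O)C1`: 50 mL/min/kg
- compound 2, `C[C@]1(O)C[C@@](c2ccc(OC(F)(F)F)cc2)([C@@H](O)c2ccccn2)C1`: 100 mL/min/kg
- compound 3, `O[C@H](c1ccccn1)C1(c2cccc(OC(F)(F)F)c2)CCC1`: 1720 mL/min/kg

All three were tested in an ADME assay on liver for metabolic stability, with Liver microsome (Rattus norvegicus) as the target, read by LC-MS, using microsomes, with a stated time of 5 h; a lower number here means slower removal, a higher number faster removal of the compound. Compound 2 gives 100 mL/min/kg, which stands second highest among the three numbers. Its nearest neighbour is compound 1, whose value of 50 mL/min/kg lies within the usual scatter of this assay, so the two cannot be told apart. Compound 3, with 1720 mL/min/kg, gives a number far above both, a difference well beyond the scatter.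

Compound 4, `C[C@]1(O)C[C@@](c2ccc(OC(F)(F)F)cc2)([C@H](O)c2ccccn2)C1`, has not yet been measured. It relates to compound 2 as follows: the two compounds have the same atoms and bonds and differ only in configuration as drawn: 2 of 3 stereo elements differ; a stereocentre at a saturated ring carbon is drawn S in compound 2 and R in compound 4; a stereocentre at a saturated chain carbon is drawn R in compound 2 and S in compound 4. Going by the values given here, no step between two measured compounds of this kind is available, so there is no direct guide to how a change in configuration alone moves the clearance here. Compound 1 and compound 2 differ in several places and still give numbers within the scatter of each other, which suggests that the readout does not swing sharply with modest changes around this core. The step of no change at the digits printed from compound 2 to compound 4 (within the scatter) is therefore expected to be small, in no clear direction, and not beyond the scatter. Compound 4 is expected to give about 100 mL/min/kg, with a likely range from 40 mL/min/kg to 300 mL/min/kg.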

Compound 4, clearance: 133 mL/min/kg
Compound 4: middle estimate off by 1.3-fold (0.12 log units), on the low side, and the stated range covers the measured number.
By their numbers in this assay, from the lowest: compounds 1, 2 and 4 (each within the scatter of the next, the first and the last beyond it); then compound 3.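

In this assay, going by these compounds alone, this pair gives the first direct reading of what configuration alone does around this core, with a 1.3-fold higher number from compound 2 to compound 4 (0.12 log units; within the scatter). Two of the three stereo elements, one at a saturated ring carbon and one at a saturated chain carbon, are drawn the opposite way, yet the two numbers cannot be told apart. The comparison is a clean one, since nothing else separates the two structures: the fact that compounds 2 and 4 differ only in the configuration as drawn.

Going by these compounds, the two changes of configuration arrive together, so what each would do alone remains unknown, as does the effect of changing the third stereo element. The compounds shown also leave open how the clearance would respond if an amine or a carboxylic acid were added to the shared core.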